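This account rests on a few compounds, and the source may have more. Where it says the series, first, only, none or still open, it means among the compounds named here.

For the measured compounds named here, compound 1, `COc1cncc(C(=O)Nc2cnn(Cc3c(C)noc3C)c2)c1`, is the stronger of the two compounds measured so far in a functional assay on cells for antagonist activity at taste receptor type 2 member 8 (Homo sapiens), read by FLIPR and calcium flux, with a stated time of 100 s; on this read-out lower numbers stand for stronger inhibition and higher numbers for weaker inhibition. In this assay compound 1 gives 800 nM. Going by the values given here, the only other measured compound, compound 2, `Cc1noc(C)c1Cn1cc(N2Cc3ccccc3C2=O)cn1`, gives 9000 nM in this assay, a higher number than that of compound 1, and the gap between the two lies well beyond the usual scatter. Compound 1 therefore stands at the low end of what has been seen here, with nothing close to it.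

Compound 3, `Cc1noc(C)c1Cn1cc(NC(=O)Nc2ccccc2)cn1`, has not yet been measured. It differs from compound 1 in one place: anilino in place of 5-methoxypyridin-3-yl on a carbonyl carbon. Among the compounds with values here, no measured pair shows this change, so there is no step to lean on. Because compound 1 gives 800 nM and the change swaps an aromatic ring bearing two acceptors for one bearing a single donor, a moderate rise in the number is expected rather than none. Compound 3 is expected to give 2000 nM, within a range of 600 nM to 8000 nM. The expected step is a 2.5-fold higher number from compound 1 to compound 3 (0.40 log units; beyond the scatter), a rise just beyond the scatter.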

Compound 3, half-maximal inhibitory concentration: 2000 nM
Compound 3: middle estimate and measured number agree at the digits printed, and the stated range covers the measured number.
By their numbers in this assay, from the lowest: compound 1; then compound 3; then compound 2.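

In this assay, anilino in place of 5-methoxypyridin-3-yl on a carbonyl carbon gives a 2.5-fold higher number from compound 1 to compound 3 (0.40 log units; beyond the scatter), a modest step but one that lies beyond the scatter. For the compounds shown here, this is the first step that can be read at this position, and it shows that the number responds to the group carried on the carbonyl carbon. It also shows that inhibition is weakened but not lost when the pyridine ring gives way to a ring of carbon only, joined through an added nitrogen, with compound 3 still giving 2000 nM. No measurement on hand accounts for the size of this step or tells which part of the change produces it.

On these data alone, the ring, its methoxy group and the linking nitrogen all change together in this single step, so their separate contributions remain open. As far as these compounds go, it also remains open how the number would respond to a plain phenyl group placed directly on the carbonyl carbon, or to a cyclohexylamino group in place of anilino.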